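The compounds below may be only part of what the source reports. "The series", "measured", "known", "first", "only" and "open" are said of these compounds alone.

Compound 1 `Cc1ccc(N2CCN(C(=O)c3oc(C)nc3-c3ccccc3)CC2)cc1` sits at the limit of a functional assay on HL-60 cells (Homo sapiens) for inhibition, read by MTT assay, with a stated time of 72 h (a higher number here means a weaker inhibitor, a lower number a stronger inhibitor), giving > 1000 nM, which is a limit rather than a number. Compound 2 `COc1cccc(N2CCN(C(=O)c3oc(C)nc3-c3ccccc3)CC2)c1` gives 34.8 nM in this assay. Compound 3 `Cc1nc(-c2ccccc2)c(C(=O)N2CCN(c3ccccc3C(F)(F)F)CC2)o1` gives 120 nM in this assay.

Among the two numbers, compound 3 has the highest; its nearest neighbour is compound 2, with a 3.4-fold higher number from compound 2 to compound 3 (0.54 log units; beyond the scatter). Compound 4 `Cc1nc(-c2ccccc2)c(C(=O)N2CCN(c3cccc(C#N)c3)CC2)o1` differs from compound 3 by 3-cyanophenyl in place of 2-(trifluoromethyl)phenyl on an amine nitrogen in a ring. Within the data shown here, the steps that bear on this are an at least 8.3-fold lower number from compound 1 to compound 3 (0.92 log units; beyond the scatter) and an at least 28-fold lower number from compound 1 to compound 2 (1.45 log units; beyond the scatter), both toward lower numbers from compound 1, and a 3.4-fold higher number from compound 2 to compound 3 (0.54 log units; beyond the scatter), a modest rise. A 3-cyanophenyl, like the 3-methoxyphenyl of compound 2, is therefore expected to lower the number by a modest step, a 2.4-fold lower number from compound 3 to compound 4 (0.38 log units; beyond the scatter). Compound 4 is estimated at 50 nM, within 15 nM to 200 nM.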

Compound 4, half-maximal inhibitory concentration: 39.6 nM
Compound 4: the middle estimate sits 1.3-fold (0.10 log units) above what was measured; measured number inside the range.
By their numbers in this assay, from the lowest: compounds 2 and 4 (each within the scatter of the next); then compound 3. At a limit, above all of these: compound 1.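

Exchanging the methoxy of compound 2 for cyano on the aromatic carbon gives a 1.1-fold higher number from compound 2 to compound 4 (0.06 log units; within the scatter), so 3-cyanophenyl and 3-methoxyphenyl on the amine nitrogen cannot be told apart in this assay. The other two changes at this position give a 3.0-fold lower number from compound 3 to compound 4 (0.48 log units; beyond the scatter) and an at least 25-fold lower number from compound 1 to compound 4 (1.40 log units; beyond the scatter), which places both 3-substituted phenyl groups ahead of 2-(trifluoromethyl)phenyl and 4-methylphenyl. Compound 1 stands at a limit, so the last step is a bound: the limit of > 1000 nM in this assay, at which 1 of the 4 values shown sits.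

The compounds shown leave open how a plain phenyl or a 3-aminophenyl would stand here. They also leave open whether a 3-carboxyphenyl would keep the number of compound 4.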